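This account rests on a few compounds, and the source may have more. Where it says the series, first, only, none or still open, it means among the compounds named here.

Measured so far in a functional assay on NCI-H460 cells (Homo sapiens) for cytotoxicity, read by MTT assay, with a stated time of 68 h; on this read-out higher numbers stand for weaker inhibition and lower numbers for stronger inhibition:
- compound 1 `Cc1ccc(-c2cccc(NC(=O)C(Cl)Cl)c2)cc1` gives 8000 nM
- compound 2 `O=C(Nc1cccc(-c2cccc(C(F)(F)F)c2)c1)C(Cl)Cl` gives 30200 nM
- compound 3 `O=C(Nc1cccc(-c2ccc(C(F)(F)F)cc2)c1)C(Cl)Cl` gives 33600 nM

Compound 4 `Cc1cccc(-c2cccc(NC(=O)C(Cl)Cl)c2)c1` has not yet been measured in this assay. It differs from compound 2 by methyl in place of trifluoromethyl on an aromatic carbon. The same kind of change, (methyl in place of trifluoromethyl on an aromatic carbon), separates compound 3 from compound 1, where it gave a 4.2-fold lower number from compound 3 to compound 1 (0.62 log units; beyond the scatter). The two places are not identical: in compound 4 the methyl sits meta to a large group, in compound 1 para to a large group. The difference between the cores of compound 2 and compound 3 is not broken down here; their two values lie within the scatter of each other. Because a 4.2-fold lower number from compound 3 to compound 1 (0.62 log units; beyond the scatter) was a modest drop, a similar step, a 3.8-fold lower number from compound 2 to compound 4 (0.58 log units; beyond the scatter), is expected here. Compound 4 is therefore estimated at 8000 nM, between 3000 nM and 20000 nM.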

Compound 4, half-maximal inhibitory concentration: 24300 nM
For compound 4 the middle estimate is 3.0-fold (0.48 log units) below the measured one; the whole stated range lies below it.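

In this assay, putting methyl in place of trifluoromethyl gives a 1.2-fold lower number from compound 2 to compound 4 (0.09 log units; within the scatter) and so makes no readable difference on this core. The same change therefore did not carry over at the same size from one core to the other: the same change on two cores in this assay, a 4.2-fold lower number (0.62 log units; beyond the scatter) from compound 3 to compound 1 and a 1.2-fold lower number (0.09 log units; within the scatter) from compound 2 to compound 4, 3.4-fold (0.53 log units) apart, beyond the scatter of two such steps. These two pairs show that the size of this step depends on the core, but they do not show why, and they give no rule for predicting the step on a further core.

The compounds shown leave open how an amine, a methoxy group or a carboxylic acid on the same aromatic carbon would compare with methyl and trifluoromethyl. They also leave open whether those groups would depend on the core in the same way.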